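The source may hold more compounds than are shown below. What is called first, only, known or untested is meant among the compounds shown, and "the series" means these compounds.

Compound 3 `CC1=C(C(=O)OCC(C)C)C(c2cc([N+](=O)[O-])cc(Br)c2O)C2=C(CC(C)(C)CC2=O)N1` gives 70% in an assay for inhibition of Voltage-dependent L-type calcium channel subunit alpha-1C (Rattus norvegicus), read by patch clamp, tested at 10 uM; on this read-out lower numbers stand for less inhibition and higher numbers for more inhibition at the one concentration tested (going by the name of the read-out). It stands level with compound 1 `CC1=C(C(=O)OCc2ccccc2)C(c2cc([N+](=O)[O-])ccc2O)C2=C(CCC(C)(C)C2=O)N1`, which gives 70% in this assay; the two values lie within the scatter of each other, so no order between them is claimed. Compound 2 `CC1=C(C(=O)OC(C)(C)C)C(c2cc([N+](=O)[O-])ccc2O)C2=C(CCC(C)(C)C2=O)N1` in this assay is reported only as a limit, < 30%; this is the limit of < 30% in this assay, at which 1 of the 3 values shown sits. For the measured compounds named here, the one step measured between compounds that differ in a single place is a number at least 40 percentage points lower from compound 1 to compound 2 (beyond the scatter), and it concerns the ester, not the aromatic ring.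

Compound 4 `CC1=C(C(=O)OCC(C)C)C(c2cc([N+](=O)[O-])ccc2O)C2=C(CC(C)(C)CC2=O)N1` differs from compound 3 in one place: hydrogen in place of bromo on an aromatic carbon. Going by the values given here, no measured pair differs by a bromo on this ring, so the step from compound 3 to compound 4 has no direct precedent in this assay. Among the compounds with values here, compound 1 carries hydrogen at that carbon and sits level with compound 3, but it also differs from compound 4 in the ester and in the shared core, so no step between them is given. Compound 4 is therefore expected to show a step of a number 15 percentage points lower from compound 3 to compound 4 (beyond the scatter) in this assay, a modest loss that could equally turn out to be no change beyond the scatter. The estimate for compound 4 in this assay is 55%, between 30% and 75%.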

Compound 4, a percentage reported as inhibition, at one concentration (the size of the read-out at that concentration, not a potency): 30%
Beside the measured number, compound 4's estimate is 25 percentage points above it; the range from low to high includes it.
By their numbers in this assay, from the lowest: compound 4; then compounds 1 and 3 (each within the scatter of the next).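

Hydrogen in place of bromo on this aromatic carbon, ortho to a hydroxy group and meta to a nitro group, brings a number 40 percentage points lower from compound 3 to compound 4 (beyond the scatter) in this assay, so a large step now rests on the loss of one bromine atom. For the compounds shown here, until now the only measured step concerned the ester, and this pair shows that a single place on the aromatic ring can also give a large step while the ester and the shared core stay the same. Nothing among the data shown accounts for why the bromo counts for this much.

As far as these compounds go, whether the step depends on bromine itself stays open, as a chloro, a methyl or a methoxy group on this carbon could fall with compound 3, with compound 4 or in the range between them. From the compounds shown here alone, this remains a single pair with one ester and one core, so it is also open whether adding bromo at this carbon would give a step of similar size with a benzyl ester or with the core of compound 1.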